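The source may report more compounds than this note shows. Statements on the series, on what has been measured and on what is new or still open speak of the compounds shown alone.

Measured compounds and their values in this assay:
Compound 1 `O=[N+]([O-])C1=CNc2nc(C(F)(F)F)nn2C1c1c(O)cc(O)cc1O`: 838000 nM
Compound 2 `O=[N+]([O-])C1=CNc2ncnn2C1c1c(O)cc(O)cc1O`: a limit, > 1030000 nM
Compound 3 `O=[N+]([O-])C1=NNc2ncnn2C1c1ccc(O)c(O)c1O`: 228000 nM

In an ADME assay on MDCK cells (Canis lupus familiaris) for cytotoxicity (on this read-out lower numbers stand for higher toxicity in this test and higher numbers for lower toxicity in this test), compound 1 gives 838000 nM. For compound 2 this assay reports only a limit, > 1030000 nM. Compound 3 gives 228000 nM, the lowest of the two numbers, with compound 1 the nearest at a higher value beyond the scatter. Compound 4 `O=[N+]([O-])C1=NNc2nc(C(F)(F)F)nn2C1c1ccc(O)c(O)c1O` is not yet measured.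

From compound 2 to compound 1 the change is trifluoromethyl in place of hydrogen on an aromatic carbon. It gave an at least 1.2-fold lower number from compound 2 to compound 1 (0.08 log units; that floor lies within the scatter). The floor of that step rests on the limit (the limit of > 1030000 nM in this assay, at which 1 of the 3 values shown sits). From compound 3 to compound 4 the same change is made: trifluoromethyl in place of hydrogen on an aromatic carbon. The difference between the two cores, that of compound 2 and that of compound 3, is not broken down here.

Beside the earlier step, the step from compound 3 to compound 4 in this assay is expected to be a 1.2-fold lower number from compound 3 to compound 4 (0.08 log units; within the scatter), resting on the small movement seen in an at least 1.2-fold lower number from compound 2 to compound 1 (0.08 log units; that floor lies within the scatter). Compound 4 is therefore estimated at about 190000 nM, expected between 70000 nM and 500000 nM.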

Compound 4, half-maximal cytotoxic concentration: 67000 nM
Beside the measured number, compound 4's estimate is 2.8-fold (0.45 log units) above it; the whole stated range lies above it.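

In this assay, trifluoromethyl in place of hydrogen on an aromatic carbon gave a 3.4-fold lower number from compound 3 to compound 4 (0.53 log units; beyond the scatter), a clear step on the core of compound 3. Whether the same change carries from one core to the other with the same size is not settled by this pair of steps: the same change on two cores in this assay, an at least 1.2-fold lower number (0.08 log units; that floor lies within the scatter) from compound 2 to compound 1 and a 3.4-fold lower number (0.53 log units; beyond the scatter) from compound 3 to compound 4; the limit leaves it open whether they differ. The earlier step has only a floor, and the value of compound 2 is a limit: the limit of > 1030000 nM in this assay, at which 1 of the 4 values shown sits.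

The compounds shown leave open how a methyl, an amine or a carboxylic acid on that aromatic carbon would move the number on either core. They also leave open what the difference between the two cores contributes on its own.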